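The compounds below may be only part of what the source reports. "The series", "measured", "known", "first", "only" and "open" are said of these compounds alone.

Three compounds have been measured:
compound 1, `CCCCCCCNc1cnc(C(=O)NCc2ccccc2)cn1`
compound 2, `CCCCCCNc1cnc(C(=O)NCc2ccccc2)cn1`
compound 3, `CCCCCCNc1nccnc1C(=O)NCc1ccccc1`

In an ADME assay on HEL cells (Homo sapiens) for cytotoxicity, read by microscopy, with a stated time of 6 days (a lower number here means that less compound is tolerated, a higher number that more compound is tolerated), compound 1 gives > 100000 nM, which is a limit of the assay and not a number. Compound 2 likewise gives > 100000 nM, again a limit. For the measured compounds named here, compound 3 gives 100000 nM, the only number among the three. Compound 1 differs from compound 2 by methyl in place of hydrogen on a saturated chain carbon, six bonds along the chain from a nitrogen on an aromatic ring. The step that the two limits leave unreadable from compound 2 to compound 1 cannot be sized, because the limit of > 100000 nM in this assay, at which 2 of the 3 values shown sit, leaves both ends unreadable. The difference between the core of compound 2 and the core of compound 3 is not broken down here.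

Compound 4, `CCCCCCCNc1nccnc1C(=O)NCc1ccccc1`, has not yet been measured. It differs from compound 3 by methyl in place of hydrogen on a saturated chain carbon, six bonds along the chain from a nitrogen on an aromatic ring, the same change as that made from compound 2 to compound 1. That earlier change left no readable step, so the expectation for compound 4 rests mainly on compound 3 and its value 100000 nM. Compound 4 is expected to give about 100000 nM. For compound 4 the expected range runs from 50000 nM to 200000 nM. The expected step is no change at the digits printed from compound 3 to compound 4 (within the scatter).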

Compound 4, minimum cytotoxic concentration: 100000 nM
Beside the measured number, compound 4's estimate shows no gap at the digits printed, within the range that was stated.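

In this assay, methyl in place of hydrogen on a saturated chain carbon, six bonds along the chain from a nitrogen on an aromatic ring, gives no change at the digits printed from compound 3 to compound 4 (within the scatter). The same change on the other core, from compound 2 to compound 1, gives a step that cannot be read, because both of its values are a limit of the assay and not a number: the limit of > 100000 nM in this assay, at which 2 of the 4 values shown sit. The change therefore has one readable step, on one core only, which shows no movement there but does not show that the change behaves alike on both cores.

The compounds shown leave open how a shorter chain, or a chain ending in an amine or a carboxylic acid, would read in this assay on either core. Also open, from the compounds shown here alone, is whether a much longer chain on the core of compound 2 would give a number there instead of a limit.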